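Swapping the anilino ring of compound 2 for a bromofluorophenyl

A few compounds are considered here, and "the series" means these few. Any claim that something is new, unique, unknown or untested is made for them only; others in the source may bear on it.

Among the measured compounds shown here, compound 2, `COc1ccc(Nc2ncnc3cc(OC)c(OCCCCC(=O)Nc4ccc(S(N)(=O)=O)cc4)cc23)cc1`, is the only compound here with a numerical result: in a functional assay on NCI-H1975 cells (Homo sapiens) for antiproliferative activity, read by MTT assay, with a stated time of 72 h (on this read-out lower numbers stand for stronger inhibition and higher numbers for weaker inhibition), compound 2 gives 30200 nM. Compound 1, `COc1cc2ncnc(Nc3ccc(F)cc3)c2cc1OCCCCC(=O)Nc1ccc(S(N)(=O)=O)cc1`, reaches only a limit of the assay; in this assay compound 1 gives > 40000 nM. For the measured compounds named here, the single measured step, an at least 1.3-fold lower number from compound 1 to compound 2 (0.12 log units; that floor lies within the scatter), is therefore bounded by the limit of > 40000 nM in this assay, at which 1 of the 2 values shown sits, and its floor lies inside the scatter.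

Compound 3, `COc1cc2ncnc(Nc3ccc(F)c(Br)c3)c2cc1OCCCCC(=O)Nc1ccc(S(N)(=O)=O)cc1`, has not been measured. It differs from compound 2 by 3-bromo-4-fluorophenyl in place of 4-methoxyphenyl on a nitrogen on an aromatic ring. Going by the values given here, the change moves back toward the fluoro-bearing ring of compound 1 while also adding a bromo group, so the step from compound 1 to compound 2 is the only measured guide, and read in reverse it points to a higher number of modest size, possibly back at the limit. The expected step in this assay is a 1.3-fold higher number from compound 2 to compound 3 (0.12 log units; within the scatter). Compound 3 is estimated at 40000 nM, with a range from 15000 nM to 100000 nM.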

Compound 3, half-maximal inhibitory concentration: 31600 nM
For compound 3 the middle estimate is 1.3-fold (0.10 log units) above the measured one, and the stated range covers the measured number.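

At this place, on a nitrogen on an aromatic ring, this assay shows a 1.0-fold higher number from compound 2 to compound 3 (0.02 log units; within the scatter), so 3-bromo-4-fluorophenyl and 4-methoxyphenyl cannot be told apart, although they differ in their substituents. Among the compounds shown here, this is the first comparison at this position between two numbers rather than against a limit. Bromo in place of hydrogen on an aromatic carbon gives an at least 1.2-fold lower number from compound 1 to compound 3 (0.10 log units; that floor lies within the scatter), so even this change cannot be sized beyond a floor: the limit of > 40000 nM in this assay, at which 1 of the 3 values shown sits.

The compounds shown leave open whether any group on this ring can move the number beyond the scatter, such as a chloro or an ethynyl group. They also leave open what a longer chain, or a carboxylic acid in place of the sulfonamide, would do in this assay.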